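The compounds below may be only part of what the source reports. "The series", "measured", "known", "first", "only" and "open" are said of these compounds alone.

Measured so far, in an assay for inhibition of inositol hexakisphosphate kinase 3 (Homo sapiens), read by colorimetric assay, coupled enzyme assay and malachite green, with a stated time of 120 min, in the presence of a further agent that is not named here; on this read-out higher numbers stand for weaker inhibition and lower numbers for stronger inhibition:
- compound 1 `O=C(O)c1ccc2noc(-c3cccc(C(F)(F)F)c3)c2c1` gives 4620 nM
- compound 2 `O=C(O)c1ccc2noc(-c3cccc(NC(=O)C4CC4)c3)c2c1` gives 2810 nM
- compound 3 `O=C(O)c1ccc2noc(-c3cccc(-c4ccccc4)c3)c2c1` gives 840 nM

Compound 3 holds the lowest number of the three in this assay; its nearest neighbour is compound 2, a 3.3-fold lower number from compound 2 to compound 3 (0.52 log units; beyond the scatter), and the furthest is compound 1, a 5.5-fold lower number from compound 1 to compound 3 (0.74 log units; beyond the scatter). Both steps sit beyond the scatter, so compound 3 is the strongest inhibitor in this small set. The step from compound 1 to compound 2 is smaller: a 1.6-fold lower number from compound 1 to compound 2 (0.22 log units; within the scatter).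

The next compound, compound 4 `O=C(O)c1ccc2noc(-c3cccc(Oc4ccccc4)c3)c2c1`, differs from compound 3 in one place: phenoxy in place of phenyl on an aromatic carbon. Both measured steps that lead to compound 3 bear on this change, since both replace a smaller group at the same aromatic carbon with a phenyl ring. Nothing measured separates a phenyl from a phenoxy at that position, so there is no basis for expecting a step beyond the scatter in this assay in either direction. The expectation is that compound 4 lands close to compound 3, with a step of a 1.2-fold higher number from compound 3 to compound 4 (0.08 log units; within the scatter) that stays within the scatter. For compound 4 the estimate in this assay is 1000 nM, with a range from 400 nM to 2500 nM.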

Compound 4, half-maximal inhibitory concentration: 850 nM
The estimate for compound 4 lay 1.2-fold (0.07 log units) above the measured number; low and high end bracket the measured number.
By their numbers in this assay, from the lowest: compounds 3 and 4 (each within the scatter of the next); then compounds 2 and 1 (each within the scatter of the next).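

In this assay, phenoxy and phenyl on this aromatic carbon cannot be told apart, with a 1.0-fold higher number from compound 3 to compound 4 (0.01 log units; within the scatter) inside the scatter, so the oxygen link between the shared core's aryl ring and the terminal phenyl ring does not separate the two compounds on this read-out. Phenoxy also stands clear of the two groups without a terminal aromatic ring, with a 3.3-fold lower number from compound 2 to compound 4 (0.52 log units; beyond the scatter) and a 5.4-fold lower number from compound 1 to compound 4 (0.74 log units; beyond the scatter) both beyond the scatter, so the advantage first seen with phenyl is now shared by two differently attached phenyl rings, while (cyclopropylcarbonyl)amino and trifluoromethyl stay at the higher end. No supporting evidence is available to explain this match between phenyl and phenoxy or their gap to the other two groups.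

Still open, going by these compounds, is whether a benzyloxy group, with its longer link, or a pyridine ring in place of the terminal phenyl would hold the number seen with compound 4. On these data alone, all four compounds carry the carboxylic acid on the shared core, so the effect of a primary amide or a tetrazole in its place remains unknown.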